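This account rests on a few compounds, and the source may have more. Where it says the series, first, only, none or still open, it means among the compounds named here.

Compound 1 `COc1cc(-c2cc(/C=C/C(=O)c3ccc(Cl)c(Cl)c3)[nH]n2)cc(OC)c1OC` carries the 3,4-dichlorophenyl on the carbonyl carbon. In a functional assay on ACHN cells (Homo sapiens) for cytotoxicity, read by sulforhodamine B assay, with a stated time of 48 h, tested at 100 uM (on this read-out higher numbers stand for a weaker effect at the one concentration tested and lower numbers for a stronger effect), compound 1 gives 16%, the highest number of the three measured and thus the weakest effect at the single concentration. Compound 2 `COc1ccc(-c2cc(/C=C/C(=O)c3ccc(N)cc3)[nH]n2)cc1OC` gives -95% and compound 3 `COc1ccc(-c2cc(/C=C/C(=O)c3ccc(N)cc3)[nH]n2)cc1` gives -73%; both lie far below compound 1, beyond the scatter. For the measured compounds named here, the only measured single-change step, a number 22 percentage points higher from compound 2 to compound 3 (beyond the scatter), comes from hydrogen in place of methoxy on an aromatic carbon and moved the number modestly upward.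

Compound 4 `COc1ccc(C(=O)/C=C/c2cc(-c3cc(OC)c(OC)c(OC)c3)n[nH]2)cc1OC` is the next step from compound 1: 3,4-dimethoxyphenyl in place of 3,4-dichlorophenyl on a carbonyl carbon. Going by the values given here, no measured pair swaps a chlorine-bearing ring for a methoxy-bearing ring on the carbonyl carbon, so this step has no direct precedent. The only indirect hint is the step from compound 2 to compound 3, where the methoxy-bearing compound gave the lower number; it is modest and sits on a different part of the molecule, and the large gap between compound 1 and the two amino-bearing compounds shows how strongly the group on the carbonyl carbon can move the number. The expected step is therefore a number 21 percentage points lower from compound 1 to compound 4 (beyond the scatter), with wide uncertainty. Compound 4 is estimated at -5%, in a range from -65% to 40%.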

Compound 4, a percentage reported as activity, at one concentration (the size of the read-out at that concentration, not a potency): -91%
For compound 4 the middle estimate is 86 percentage points above the measured one, outside the stated range (below it).
By their numbers in this assay, from the lowest: compounds 2 and 4 (each within the scatter of the next); then compound 3; then compound 1.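

For the compounds shown here, replacing 3,4-dichlorophenyl with 3,4-dimethoxyphenyl on the carbonyl carbon gives a number 107 percentage points lower from compound 1 to compound 4 (beyond the scatter) in this assay, so a change in this one place, with the rest of the molecule held fixed, can move the number a long way, whereas the only earlier single-change step, a number 22 percentage points higher from compound 2 to compound 3 (beyond the scatter), was modest. Going by these compounds alone, compound 1 differs from compound 2 and compound 3 in more than one place, so the earlier compounds left the group on the carbonyl carbon unisolated; this pair isolates it and shows the number passing from positive in compound 1 at 16% to negative in compound 4 at -91%. Nothing available here gives a measured reason for the size of this step.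

From the compounds shown here alone, it remains open whether the step follows from gaining the methoxy groups or from losing the chlorines, a question that a plain phenyl or a phenyl bearing a single methoxy on the carbonyl carbon would help to settle. Going by these compounds, how a phenyl bearing a carboxylic acid or a nitrile would read at this position also remains open.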